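A few compounds are considered here, and "the series" means these few. Any claim that something is new, unique, unknown or untested is made for them only; others in the source may bear on it.

Measured in an ADME assay on HepG2 cells (Homo sapiens) for cytotoxicity, read by MTT assay, with a stated time of 72 h; a lower number here means that less compound is tolerated, a higher number that more compound is tolerated:
- Compound 1 `COc1ccc(-c2cc(Cl)cn3c([N+](=O)[O-])c(CS(=O)(=O)c4ccccc4)nc23)cc1`: > 3900 nM, a limit
- Compound 2 `O=[N+]([O-])c1c(CS(=O)(=O)c2ccccc2)nc2c(-c3ccccc3CO)cc(Cl)cn12`: 88000 nM
- Compound 3 `O=[N+]([O-])c1c(CS(=O)(=O)c2ccccc2)nc2c(-c3ccccc3F)cc(Cl)cn12`: > 3900 nM, a limit

Compound 3 has only a limit, not a number. It stands at the limit of > 3900 nM in this assay, at which 2 of the 3 values shown sit.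

Compound 4 `O=[N+]([O-])c1c(CS(=O)(=O)c2ccccc2)nc2c(-c3ccc(C(F)(F)F)cc3)cc(Cl)cn12` carries 4-(trifluoromethyl)phenyl in place of the 2-fluorophenyl of compound 3, on the same aromatic carbon: 4-(trifluoromethyl)phenyl in place of 2-fluorophenyl on an aromatic carbon.

Three measured steps change the group at this place: a step that the two limits leave unreadable from compound 1 to compound 3, a step that the limit leaves unreadable from compound 2 to compound 3 and a step that the limit leaves unreadable from compound 1 to compound 2. None has a size that can be carried over, so no direction can be expected from them in this assay. No step beyond the scatter is expected, and the estimated move is a step that the limit leaves unreadable from compound 3 to compound 4. Among the compounds with values here, the single true number, compound 2 at 88000 nM, guides the upper side of the range. For compound 4 the expected value is 7000 nM, with an estimated range of 3000 nM to 40000 nM.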

Compound 4, half-maximal cytotoxic concentration: > 3900 nM
Compound 4 ended at the assay's limit (the forecaster's own chance of this, stated with the estimate: 70%); the middle value lies beyond the limit too.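

Compound 4 gives only a limit in this assay, so its steps to compound 1, compound 2 and compound 3 cannot be read: the limit of > 3900 nM in this assay, at which 3 of the 4 values shown sit. From the compounds shown here alone, the true values of compound 1, compound 3 and compound 4 stay open, and so does how each compares with compound 2.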